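Adding two chlorines to the benzyl group of compound 1

A few compounds are considered here, and "the series" means these few. Any claim that something is new, unique, unknown or untested is made for them only; others in the source may bear on it.

For the measured compounds named here, in a functional assay on CNE2Z cells (Homo sapiens) for inhibition, read by MTT assay, with a stated time of 72 h (a lower number here means a stronger inhibitor, a higher number a weaker inhibitor), compound 1 `C=CCc1ccc(O)c(-c2ccc(OCc3ccccc3)c(CC=C)c2)c1` gives 30300 nM, the only actual number available so far in this small series. Compound 2 `C=CCc1ccc(OCc2ccc(Cl)cc2Cl)c(-c2ccc(OCc3ccc(Cl)cc3Cl)c(CC=C)c2)c1` gives > 50000 nM in this assay, and this is a limit of the assay rather than a number. Going by the values given here, compound 1 therefore stands alone as the single measured reference point, and the series offers no measured pair that differ in just one place.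

Compound 3 `C=CCc1ccc(O)c(-c2ccc(OCc3ccc(Cl)c(Cl)c3)c(CC=C)c2)c1` keeps the core of compound 1 and changes in one place only: 3,4-dichlorophenyl in place of phenyl on a saturated chain carbon bound to an oxygen on an aromatic ring. This puts 3,4-dichlorophenyl in place of phenyl on a saturated chain carbon bound to an oxygen on an aromatic ring, so that benzyl becomes 3,4-dichlorobenzyl. Among the compounds with values here, with no measured step to lean on, only a small shift is anticipated, leaning slightly toward stronger inhibition and probably not clearing the usual scatter. The estimated change is a 1.5-fold lower number from compound 1 to compound 3 (0.18 log units; within the scatter). In this assay the expected value for compound 3 is 20000 nM, with an estimated range of 8000 nM to 45000 nM.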

Compound 3, half-maximal inhibitory concentration: 17800 nM
Beside the measured number, compound 3's estimate is 1.1-fold (0.05 log units) above it; measured number inside the range.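

Swapping phenyl for 3,4-dichlorophenyl on a saturated chain carbon bound to an oxygen on an aromatic ring gives, in this assay, a 1.7-fold lower number from compound 1 to compound 3 (0.23 log units; within the scatter) and so leaves compound 1 and compound 3 indistinguishable. For the compounds shown here, this is the first step that can be read from two actual numbers, and it shows that this position accepts the two chlorines, with compound 3 still giving a measured 17800 nM while the free hydroxyl of the core is kept. Compound 2 gives > 50000 nM as a limit of the assay and not a number, and since it differs from compound 1 in more than one place, no step can be read from it.

Nothing among the measurements shown speaks to why the two chlorines leave the number within the scatter. On these data alone, it remains open whether a single chlorine, an amine or a carboxylic acid on the benzyl ring, or a longer chain between that ring and the oxygen, would move the number beyond the scatter in either direction.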